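The source may report more compounds than this note shows. Statements on the series, on what has been measured and on what is new or still open speak of the compounds shown alone.

Working notes on the shared core, read in a functional assay on MIA PaCa-2 cells (Homo sapiens) for inhibition, read by MTT assay, with a stated time of 3 days; a lower number here means a stronger inhibitor, a higher number a weaker inhibitor. Compound 1 (`CCN(CC)S(=O)(=O)c1ccc(S(=O)(=O)N2CCC[C@@H](C(=O)N3CCC(O)CC3)C2)cc1`) gives 230 nM, compound 2 (`CCN(CC)S(=O)(=O)c1ccc(S(=O)(=O)N2CCC[C@@H](C(=O)N3CCC(OC)CC3)C2)cc1`) gives 50 nM, and compound 3 (`CCN(CC)S(=O)(=O)c1ccc(S(=O)(=O)N2CCC[C@@H](C(=O)N[C@H]3CCOC3)C2)cc1`) gives 290 nM. Compound 3 is not separated from the 4-hydroxypiperidin-1-yl amide, with a 1.3-fold higher number from compound 1 to compound 3 (0.10 log units; within the scatter). It is clearly separated from the 4-methoxypiperidin-1-yl amide, with a 5.8-fold higher number from compound 2 to compound 3 (0.76 log units; beyond the scatter).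

Next in the series is compound 4 (`CCN(CC)S(=O)(=O)c1ccc(S(=O)(=O)N2CCC[C@@H](C(=O)N[C@H]3CC[C@@H](OC)CC3)C2)cc1`), which carries 4-methoxycyclohexyl in place of oxolan-3-yl on an amide-type nitrogen. Among the measured compounds shown here, no measured compound carries this ring, so the guidance is indirect. Compound 2 also bears a methoxy group, and the only other gain in the series is a 4.6-fold lower number from compound 1 to compound 2 (0.66 log units; beyond the scatter), which adds that methyl. A modest move toward a lower number is therefore expected, somewhat smaller than the gap to compound 2, as a 3.2-fold lower number from compound 3 to compound 4 (0.51 log units; beyond the scatter) estimates. Compound 4 is estimated at 90 nM, with an expected range of 30 nM to 270 nM.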

Compound 4, half-maximal inhibitory concentration: 590 nM
Compound 4: middle estimate off by 6.6-fold (0.82 log units), on the low side, and the stated range ends below it.
By their numbers in this assay, from the lowest: compound 2; then compounds 1 and 3 (each within the scatter of the next); then compound 4.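

In this assay, the methoxy group brings no gain on the amide-type nitrogen: 4-methoxycyclohexyl in place of oxolan-3-yl raises the number (a 2.0-fold higher number from compound 3 to compound 4 (0.31 log units; beyond the scatter)), against the drop seen when the methyl was added on the piperidine side (a 4.6-fold lower number from compound 1 to compound 2 (0.66 log units; beyond the scatter)). Keeping the methoxy group but moving to (4-methoxycyclohexyl)amino from 4-methoxypiperidin-1-yl gives the largest step in the series (a 12-fold higher number from compound 2 to compound 4 (1.07 log units; beyond the scatter)), and the number also rises from the 4-hydroxypiperidin-1-yl amide (a 2.6-fold higher number from compound 1 to compound 4 (0.41 log units; beyond the scatter)), so the benefit of methoxy is confined to compound 2 and compound 4 goes against any general methoxy trend. No available evidence accounts for this reversal.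

Going by these compounds, it remains open how much of the rise belongs to the cyclohexyl ring and how much to its methoxy group. A plain cyclohexyl amide or a 4-aminopiperidin-1-yl amide would help separate the two.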